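This account rests on a few compounds, and the source may have more. Where it says the series, first, only, none or still open, it means among the compounds named here.

Compound 1 `Clc1ccccc1COc1ccccc1/C=C/C(/C=C/c1ccccn1)=N/Oc1ncnc2ccccc12` and compound 2 `Cc1cccc(COc2ccc(/C=C/C(/C=C/c3ccccn3)=N/Oc3ncnc4cccc(C)c34)cc2)c1` were both examined in a functional assay on SMMC-7721 cells (Homo sapiens) for inhibition, read by MTT assay, with a stated time of 72 h, tested at 10 uM; a lower number here means a weaker effect, a higher number a stronger effect of the compound at the concentration tested. In this assay compound 1 gives 96%, and compound 2 gives 97%. Compound 2 holds the higher of the two numbers shown, though the gap to compound 1 lies within the scatter. Compound 3 `Cc1cccc(COc2ccc(/C=C/C(/C=C/c3ccccn3)=N/Oc3ncnc4cc(Cl)ccc34)cc2)c1` carries 7-chloroquinazolin-4-yl in place of 5-methylquinazolin-4-yl on an oxygen. For the measured compounds named here, no step between measured compounds bears on this change, so no movement beyond the scatter is expected in this assay. Compound 3 is expected to give 93%, within a range from 80% to 99%. The expected step is a number 4 percentage points lower from compound 2 to compound 3 (within the scatter).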

Compound 3, a percentage reported as inhibition, at one concentration (the size of the read-out at that concentration, not a potency): 95.6%
The estimate for compound 3 lay 2.6 percentage points below the measured number; low and high end bracket the measured number.
By their numbers in this assay, from the lowest: compounds 3, 1 and 2 (each within the scatter of the next).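

Exchanging 5-methylquinazolin-4-yl for 7-chloroquinazolin-4-yl, on an oxygen whose other neighbours are double-bonded nitrogen, gives in this assay a number 1.4 percentage points lower from compound 2 to compound 3 (within the scatter). For the compounds shown here, this is the first step to bear on this place, and it shows that the two groups cannot be told apart here, though a read-out at one concentration says nothing about potency. Nothing available explains this outcome. From the compounds shown here alone, whether an amine or a carboxylic acid in place of the chlorine would hold the read-out remains open. So does whether compound 2 and compound 3 would separate at a lower concentration.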